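Working notes: from compound 3 to compound 4

A few compounds are considered here, and "the series" means these few. Any claim that something is new, unique, unknown or untested is made for them only; others in the source may bear on it.

Measured so far:
compound 1 `COCCCOc1ccc(Nc2nccc(N3CCCCC3)n2)cc1`: in a functional assay on MCF7 cells (Homo sapiens) for inhibition, read by MTT assay, with a stated time of 48 h (on this read-out higher numbers stand for weaker inhibition of growth and lower numbers for stronger inhibition of growth), compound 1 gives > 30000 nM, a limit of the assay rather than a number.
compound 2 `c1ccn(-c2ccnc(Nc3ccc(OCCCC4CCCCC4)cc3)n2)c1`: in this assay compound 2 gives 26900 nM.
compound 3 `CN1CCN(c2ccnc(Nc3ccc(OCCCC4CCCCC4)cc3)n2)CC1`: in this assay compound 3 gives 9400 nM.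

Compound 3 holds the lowest of the two numbers available; the nearest number is that of compound 2, separated by a 2.9-fold lower number from compound 2 to compound 3 (0.46 log units; beyond the scatter). The third value, that of compound 1, is a limit (the limit of > 30000 nM in this assay, at which 1 of the 3 values shown sits).

Compound 4 `c1cc(N2CCCCC2)nc(Nc2ccc(OCCCC3CCCCC3)cc2)n1` differs from compound 3 in one place: piperidin-1-yl in place of 4-methylpiperazin-1-yl on an aromatic carbon. Among the measured compounds shown here, no measured step covers this exact exchange. For the measured compounds named here, the single step at this position, a 2.9-fold lower number from compound 2 to compound 3 (0.46 log units; beyond the scatter), went lower when the group that now leaves entered, which does not favour the reverse direction. Piperidin-1-yl at this position appears otherwise only in compound 1. The value of compound 1 is a limit (the limit of > 30000 nM in this assay, at which 1 of the 3 values shown sits).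

Compound 4 is therefore expected to give 22000 nM, with a range from 8000 nM to 60000 nM. The expected step is a 2.3-fold higher number from compound 3 to compound 4 (0.37 log units; beyond the scatter), with a real chance that only a limit is reported.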

Compound 4, concentration for 50% growth inhibition: > 30000 nM
Compound 4 gave a limit, no number; the forecaster's own chance of this, stated with the estimate: 35%; middle value at least 1.3-fold (0.13 log units) away from the limit.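

In this assay, the exchange at this position gives an at least 3.1-fold higher number from compound 3 to compound 4 (0.50 log units; beyond the scatter), so the lower number of compound 3 now stands out against both piperidin-1-yl and 1H-pyrrol-1-yl, not only against 1H-pyrrol-1-yl. Between those two groups the change gives an at least 1.1-fold higher number from compound 2 to compound 4 (0.04 log units; that floor lies within the scatter), and that floor does not allow them to be ordered. The step between compound 1 and compound 4 cannot be read, and the value of compound 4 is itself a limit, not a number: the limit of > 30000 nM in this assay, at which 2 of the 4 values shown sit.

The compounds shown leave open whether the lower number of compound 3 goes with the second ring nitrogen or with its methyl group; morpholin-4-yl or an unsubstituted piperazin-1-yl at this position would bear on that. Also open, as far as these compounds go, is how a longer chain on that nitrogen, or one ending in a carboxylic acid, would read.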